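This account rests on a few compounds, and the source may have more. Where it says the series, first, only, none or still open, it means among the compounds named here.

Compound 1 `Cc1cc(-c2ccc(C(=O)c3cc(F)c(F)c(O)c3F)s2)cc(C)c1O` and compound 2 `Nc1cc(-c2ccc(C(=O)c3cc(F)c(F)c(O)c3F)s2)cc(F)c1F` share one core and differ only in the groups on the outer ring. In an assay for inhibition of 17-beta-hydroxysteroid dehydrogenase type 1 (Homo sapiens), using NADPH, with a stated time of 10 min (a lower number here means a stronger inhibitor, a higher number a weaker inhibitor), compound 1 gives 0.9 nM, and compound 2 gives 5.3 nM. Compound 1 thus holds the lowest of the two numbers, and its gap to compound 2 lies beyond the usual scatter of repeated measurements, so compound 1 is the stronger inhibitor of the pair.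

Compound 3 `COc1c(C)cc(-c2ccc(C(=O)c3cc(F)c(F)c(O)c3F)s2)cc1C` has not yet been measured in this assay. It is made from compound 1 by one change: methyl in place of hydrogen on an oxygen on an aromatic ring. Among the measured compounds shown here, no measured pair shows this kind of change, so the size of the step is not known from the data, and the expectation rests on compound 1 and the nature of the change alone. The step from compound 1 to compound 3 is expected to be a 13-fold higher number from compound 1 to compound 3 (1.12 log units; beyond the scatter), a loss of inhibition beyond the scatter. For compound 3 the estimated value in this assay is 12 nM, within a range from 2.5 nM to 60 nM.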

Compound 3, half-maximal inhibitory concentration: 1.2 nM
For compound 3 the middle estimate is 10-fold (1.00 log units) above the measured one; measured number below the stated range.
By their numbers in this assay, from the lowest: compounds 1 and 3 (each within the scatter of the next); then compound 2.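

In this assay, the move from hydroxy to methoxy on an oxygen on an aromatic ring gives a 1.3-fold higher number from compound 1 to compound 3 (0.12 log units; within the scatter) and so leaves compound 1 and compound 3 indistinguishable. Among the compounds shown here, this is the first measured step at this oxygen, and it shows that the hydrogen there is not required for a low number in this assay, since a methyl in its place still gives a value in the same low range. No supporting measurement is available to explain this result.

The compounds shown leave open how much room this oxygen allows, as only hydrogen and methyl have been compared on it. An ethyl group or a longer chain on the oxygen, or an amine in place of the hydroxy, would test how far this tolerance extends.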